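A few compounds are considered here, and "the series" means these few. Any claim that something is new, unique, unknown or untested is made for them only; others in the source may bear on it.

Measured compounds in a functional assay on CHO cells for agonist activity at prostaglandin E2 receptor EP2 subtype (Homo sapiens), read by HTRF and cAMP accumulation, with a stated time of 30 min; a lower number here means that less compound is needed, a higher number that more compound is needed for the effect:
compound 1 `O=C(O)c1csc([C@H]2CC[C@@H]3[C@@H](/C=C/COc4ccccc4)[C@H](O)C[C@@H]3O2)n1` gives 3.8 nM;
compound 2 `O=C(O)c1csc([C@H]2CC[C@@H]3[C@@H](/C=C/[C@@H](O)COc4ccccc4)[C@H](O)C[C@@H]3O2)n1` gives 7.9 nM;
compound 3 `O=C(O)c1csc([C@H]2CC[C@@H]3[C@@H](COc4ccccc4F)[C@H](O)C[C@@H]3O2)n1` gives 23 nM.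

Compound 3 carries the highest of the three numbers in this assay, beyond the scatter from both compound 2 and compound 1; compound 1 shows the lowest number. Going by the values given here, the one single-place step recorded, a 2.1-fold higher number from compound 1 to compound 2 (0.32 log units; beyond the scatter), concerns a hydroxyl on the chain and not the aryl ring, so it does not bear on the change at hand.

Compound 4 `O=C(O)c1csc([C@H]2CC[C@@H]3[C@@H](COc4cccc(Cl)c4)[C@H](O)C[C@@H]3O2)n1` differs from compound 3 only on the phenoxy ring: 3-chlorophenyl in place of 2-fluorophenyl on an oxygen on a saturated carbon. Among the compounds with values here, no measured pair isolates a change in the substitution of that ring, and the three measured compounds give no basis to read this exchange as either favourable or unfavourable in this assay. The step of a 1.0-fold lower number from compound 3 to compound 4 (0.02 log units; within the scatter) is therefore expected to fall within the scatter. For compound 4 the estimate in this assay is 22 nM, with a range from 7 nM to 70 nM.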

Compound 4, half-maximal effective concentration: 6.5 nM
For compound 4 the middle estimate is 3.4-fold (0.53 log units) above the measured one; the measured number lies below the stated range.
By their numbers in this assay, from the lowest: compounds 1, 4 and 2 (each within the scatter of the next, the first and the last beyond it); then compound 3.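

In this assay, going by these compounds alone, the ring on the oxygen on a saturated carbon proves sensitive to substitution: 3-chlorophenyl in place of 2-fluorophenyl gives a 3.5-fold lower number from compound 3 to compound 4 (0.55 log units; beyond the scatter) and is the only measured step at this ring. The exchange alters both the halogen and its place on the ring, so this single step cannot assign the difference to either one. Nothing available explains the size or direction of this step.

Still open, as far as these compounds go, is whether 3-fluorophenyl or 2-chlorophenyl on the same oxygen would track compound 3 or compound 4, which would separate the halogen from its place on the ring. Also open, from the compounds shown here alone, is whether 3-chlorophenyl gives a comparable step on the double-bonded chain of compound 1, or whether an unsubstituted phenyl matches either halogenated ring on the chain of compound 3.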